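Swapping the trimethoxyphenyl end of a dienone for thiophene

A few compounds are considered here, and "the series" means these few. Any claim that something is new, unique, unknown or untested is made for them only; others in the source may bear on it.

Measured compounds:
- compound 1, `COc1cc(/C=C/C(=O)/C=C/c2cc(OC)c(OC)c(OC)c2)ccc1OCc1cn(CCOc2cc(=O)oc3ccccc23)nn1`: 4680 nM
- compound 2, `COc1cc(/C=C/C(=O)/C=C/c2cc(OC)c(OC)c(OC)c2)ccc1OCc1cn(CCCOc2cc(=O)oc3ccccc23)nn1`: 10600 nM

Both compounds were tested in a functional assay on COLO 205 cells (Homo sapiens) for cytotoxicity, read by sulforhodamine B assay, with a stated time of 48 h; a higher number here means a weaker inhibitor, a lower number a stronger inhibitor. Compound 1 gives 4680 nM, the lowest of the two numbers, while compound 2 gives 10600 nM, a gap that lies beyond the usual scatter. Compound 1 therefore stands as the stronger of the two, though only two points are known.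

Compound 3, `COc1cc(/C=C/C(=O)/C=C/c2cccs2)ccc1OCc1cn(CCOc2cc(=O)oc3ccccc23)nn1`, has not yet been measured. It keeps the shared core of compound 1 but differs in one place: thiophen-2-yl in place of 3,4,5-trimethoxyphenyl on a double-bonded chain carbon bound to a double-bonded chain carbon. The group that leaves carries three oxygen acceptors on a six-membered ring; the group that enters is a smaller five-membered ring with one sulfur.

Within the data shown here, no measured pair shows what such a swap does in this assay, so the expectation rests on the change alone. The number is expected to move upward, meaning a weaker inhibitor, by a step of moderate size, and compound 3 is estimated at 8000 nM, within 2500 nM to 25000 nM. The step this estimate implies is a 1.7-fold higher number from compound 1 to compound 3 (0.23 log units; within the scatter).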

Compound 3, half-maximal inhibitory concentration: 11400 nM
Compound 3: middle estimate off by 1.4-fold (0.15 log units), on the low side; low and high end bracket the measured number.
By their numbers in this assay, from the lowest: compound 1; then compounds 2 and 3 (each within the scatter of the next).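

In this assay, thiophen-2-yl in place of 3,4,5-trimethoxyphenyl on a double-bonded chain carbon bound to a double-bonded chain carbon gives a 2.4-fold higher number from compound 1 to compound 3 (0.39 log units; beyond the scatter), so this end of the molecule does affect the read-out, and the 3,4,5-trimethoxyphenyl form is the stronger inhibitor of this pair. The swap takes the group from 12 heavy atoms and 3 hydrogen-bond acceptors to 5 heavy atoms and 1 hydrogen-bond acceptor, and it also changes the ring itself, so this one pair cannot separate these changes from one another. Nothing available here explains why the number rises.

A phenyl group with no methoxy groups, a 4-methoxyphenyl group or a furan-2-yl group at this place could show which part of the change matters, but the compounds shown do not settle that. On these data alone, it also remains open whether thiophen-2-yl would have a similar effect on the longer chain of compound 2.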